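Flipping one ring stereocentre in a cyclopropane acid

The source may report more compounds than this note shows. Statements on the series, on what has been measured and on what is new or still open speak of the compounds shown alone.

Compound 1 `Cc1nn(-c2ccccn2)c2cc(-c3ccc([C@H]4C[C@@H]4C(=O)O)cc3)ccc12` and compound 2 `Cc1nn(-c2ccccn2)c2cc(-c3ccc([C@H]4C[C@H]4C(=O)O)cc3)ccc12` share the same atoms and bonds and differ only in configuration as drawn (the fact that compounds 1 and 2 differ only in the configuration as drawn). In a functional assay on cells for agonist activity at Free fatty acid receptor 1 (Mus musculus), read by FLIPR and calcium flux, with a stated time of 5 min (on this read-out lower numbers stand for smaller maximal responses and higher numbers for larger maximal responses), compound 1 gives 6%; 10% (2 entries), a small maximal response seen across repeated entries (the several entries of compound 1 in this assay, 6%; 10% (2 entries)). In this assay compound 2 gives 81%, the largest response among the numbers shown here, and the only single number it has, beside one further entry that carries no single number.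

The step now taken leads from compound 2 to compound 3 `Cc1nn(-c2ccccn2)c2cc(-c3ccc([C@@H]4C[C@H]4C(=O)O)cc3)ccc12`. The change is the two compounds have the same atoms and bonds and differ only in configuration as drawn: 1 of 2 stereo elements differ; a stereocentre at a saturated ring carbon is drawn S in compound 2 and R in compound 3. Within the data shown here, no measured pair in this set reports a step of exactly this kind, so its size has to be estimated. Because compound 1 and compound 2 differ only in configuration as drawn the fact that compounds 1 and 2 differ only in the configuration as drawn and yet give such different maximal responses, a single inversion at a saturated ring carbon can move efficacy well beyond the scatter in either direction. A sizeable drop in this assay is expected, a number 46 percentage points lower from compound 2 to compound 3 (beyond the scatter). Compound 3 is therefore estimated at 35%, within a range from 5% to 85%.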

Compound 3, largest response reached (reported as efficacy), in percent of the reference or control that the assay uses: 2%
Estimate against measurement, compound 3: 33 percentage points above; measured number below the stated range.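

In this assay, inversion at this one saturated ring carbon is enough to remove nearly all of the response of compound 2, with a number 79 percentage points lower from compound 2 to compound 3 (beyond the scatter). The earlier pair had shown that configuration matters in this series, and this step shows that the large maximal response is not shared by every form carrying the same atoms and bonds: among the three forms shown, only compound 2 reaches a large one. Compound 1 gives 6%; 10% (2 entries) and compound 3 gives 2%, so both of these forms stay small, although they too are different arrangements of a single structure: the fact that compounds 1 and 3 differ only in the configuration as drawn.

The compounds shown cover only three arrangements of the two ring carbons, so the response of any other arrangement remains open. As far as these compounds go, it is also open whether the large response of compound 2 would survive a methyl group added to the cyclopropane ring, or a longer chain between the ring and the carboxylic acid.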